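This account rests on a few compounds, and the source may have more. Where it says the series, first, only, none or still open, it means among the compounds named here.

Three compounds have numbers in hand:

Compound 1 `COc1ccc(/C=N/NC(=O)Nc2ccc(Oc3ccnc4cc(OCCCN5CCCCC5)c(OC)cc34)c(F)c2)cc1` gives 590 nM in a functional assay on HT-29 cells (Homo sapiens) for cytotoxicity, read by MTT assay, with a stated time of 72 h; on this read-out lower numbers stand for stronger inhibition and higher numbers for weaker inhibition.
Compound 2 `COc1cc2c(Oc3ccc(NC(=O)N/N=C/c4ccc(Cl)cc4Cl)cc3F)ccnc2cc1OCCCN1CCCCC1` gives 370 nM in this assay.
Compound 3 `COc1cc2c(Oc3ccc(NC(=O)N/N=C/c4ccc(OC(F)(F)F)cc4)cc3F)ccnc2cc1OCCCN1CCCCC1` gives 510 nM in this assay.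

Compound 3 holds the second highest of these three numbers. Its nearest neighbour is compound 1, with a 1.2-fold lower number from compound 1 to compound 3 (0.06 log units; within the scatter), and its furthest is compound 2, with a 1.4-fold higher number from compound 2 to compound 3 (0.14 log units; within the scatter). Compound 4 `COc1ccc(/C=N/NC(=O)Nc2ccc(Oc3ccnc4cc(OCCCN5CCCCC5)c(OC)cc34)c(F)c2)c(OC)c1` differs from compound 3 in one place: 2,4-dimethoxyphenyl in place of 4-(trifluoromethoxy)phenyl on a carbon with a double bond to nitrogen.

All three measured steps bear on this change, since each of them alters the aryl group on that same carbon. Exchanging one aryl group for another gave a 1.6-fold lower number from compound 1 to compound 2 (0.20 log units; within the scatter) and a 1.4-fold higher number from compound 2 to compound 3 (0.14 log units; within the scatter), and the change on the oxygen of that aryl group gave a 1.2-fold lower number from compound 1 to compound 3 (0.06 log units; within the scatter). Within the data shown here, compound 4 carries a 2,4-dimethoxyphenyl, which of the measured groups comes closest to the 4-methoxyphenyl of compound 1, and no step among the measured compounds reached beyond the scatter. A step of no more than the usual scatter is therefore expected in this assay. Compound 4 is expected to give about 550 nM, in a range from 250 nM to 1200 nM. That estimate corresponds to an expected 1.1-fold higher number from compound 3 to compound 4 (0.03 log units; within the scatter).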

Compound 4, half-maximal inhibitory concentration: 1600 nM
For compound 4 the middle estimate is 2.9-fold (0.46 log units) below the measured one; the whole stated range lies below it.
By their numbers in this assay, from the lowest: compounds 2, 3 and 1 (each within the scatter of the next); then compound 4.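

Until now, exchanging the aryl group on the carbon with a double bond to nitrogen had not moved the number beyond the scatter, but in this assay this position proves sensitive to the change, with a 3.1-fold higher number from compound 3 to compound 4 (0.50 log units; beyond the scatter) and a 4.3-fold higher number from compound 2 to compound 4 (0.64 log units; beyond the scatter). The closest comparison shows that one added group is enough: methoxy in place of hydrogen on an aromatic carbon gives a 2.7-fold higher number from compound 1 to compound 4 (0.43 log units; beyond the scatter), so compound 4 stands apart from the other three, which remain within the scatter of one another despite their different aryl groups. Nothing measured here accounts for this loss of activity.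

The compounds shown do not reveal whether the effect is specific to methoxy, or whether a hydroxy, ethoxy or dimethylamino group in place of the added methoxy would give a similar step. They also leave open whether the same step would appear with a different chain in place of the 3-(piperidin-1-yl)propoxy chain that all four compounds share.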